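This account rests on a few compounds, and the source may have more. Where it says the series, first, only, none or still open, it means among the compounds named here.

Three members of the series have been tested in an assay on isolated protein for inhibition of receptor-type tyrosine-protein phosphatase C (Homo sapiens); on this read-out higher numbers stand for weaker inhibition and lower numbers for stronger inhibition. Compound 1 `CO[C@@]12Cc3ccc(cc3)O[C@H]3[C@H]([C@H]4C(=O)[C@](C[C@@H](O)[C@]4(C)C=O)(C1)C(=O)N2)[C@@H](C(C)=O)[C@]1(C)C[C@H](C)C[C@H](C)[C@@H]31` gives only the limit of this assay, > 200000 nM. Compound 2 `CC(=O)[C@@H]1[C@@H]2[C@H](Oc3ccc(cc3)C[C@]3(O)C[C@]4(C[C@@H](O)[C@](C)(C=O)[C@@H]2C4=O)C(=O)N3)[C@@H]2[C@@H](C)C[C@@H](C)C[C@]21C`, carrying hydrogen in place of methyl on an oxygen on a saturated carbon, likewise returns the limit, > 200000 nM. The step that the two limits leave unreadable from compound 1 to compound 2 therefore has no readable size. Compound 3 `C[C@@H]1C[C@H](C)[C@H]2[C@H]3Oc4ccc(cc4)C[C@]4(O)C[C@]5(C[C@H](O)OO[C@@]6(C)[C@H]7O[C@@]7(C)[C@H]([C@H]3[C@H]6C5=O)[C@]2(C)C1)C(=O)N4` also stands at the limit, > 200000 nM. All three values share (the limit of > 200000 nM in this assay, at which 3 of the 3 values shown sit). Compound 4 `CO[C@@]12Cc3ccc(cc3)O[C@H]3[C@@H]4[C@H]5C(=O)[C@](C[C@H](O)OO[C@@]5(C)[C@H]5O[C@@]5(C)[C@H]4[C@]4(C)C[C@H](C)C[C@H](C)[C@@H]34)(C1)C(=O)N2` differs from compound 3 by methyl in place of hydrogen on an oxygen on a saturated carbon. Among the measured compounds shown here, the one comparable step, a step that the two limits leave unreadable from compound 1 to compound 2, runs in the opposite direction and is unreadable, so no shift beyond the scatter is expected. For compound 4 the expected value in this assay is 250000 nM, with a range of 100000 nM to 600000 nM, the expected step being a step that the limit leaves unreadable from compound 3 to compound 4.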

Compound 4, half-maximal inhibitory concentration: > 200000 nM
Compound 4: no number, only a limit; the forecaster's own chance of this, stated with the estimate: 85%; the middle value does not contradict the limit.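

Compound 4 returns only a limit, > 200000 nM, as compound 3 does, so no step can be read between compound 3 and compound 4. The compounds shown leave open whether any structural change gives readable inhibition: the limit of > 200000 nM in this assay, at which 4 of the 4 values shown sit.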